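The source may hold more compounds than are shown below. What is called first, only, known or untested is meant among the compounds shown, and "the series" means these compounds.

Measured compounds:
compound 2, `C=CCn1c(=O)/c(=C\c2cc(F)ccc2C)[nH]c(=O)/c1=C\c1ccccc1OC`: 7300 nM
compound 1, `C=CCn1c(=O)/c(=C\c2ccc(Cl)c(Cl)c2)[nH]c(=O)/c1=C\c1ccccc1OC`: "not active" (no number reported)

Within the data shown here, in a functional assay on NCI-H1975 cells (Homo sapiens) for cytotoxicity, read by CCK-8 assay, with a stated time of 72 h (a lower number here means a stronger inhibitor, a higher number a weaker inhibitor), compound 2 gives 7300 nM, the only numerical value in this set. Among the measured compounds shown here, compound 1 is reported in this assay as "not active" (no number reported), without a number, so no step between measured compounds can be stated and compound 2 stands alone as the single reference point. Compound 3, `C=CCn1c(=O)/c(=C\c2ccccc2F)[nH]c(=O)/c1=C\c1ccccc1OC`, has not yet been measured. It differs from compound 2 in one place: 2-fluorophenyl in place of 5-fluoro-2-methylphenyl on a double-bonded chain carbon bound to an aromatic carbon. For the measured compounds named here, with no measured step to draw on, the size of the move from compound 2 to compound 3 in this assay is open; a step within the scatter, or a modest move toward weaker inhibition, is expected rather than a large gain. Compound 3 is therefore expected to give 10000 nM, with a range from 3000 nM to 35000 nM. The expected step is a 1.4-fold higher number from compound 2 to compound 3 (0.14 log units; within the scatter).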

Compound 3, half-maximal inhibitory concentration: 25100 nM
For compound 3 the middle estimate is 2.5-fold (0.40 log units) below the measured one, and the stated range covers the measured number.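

Replacing 5-fluoro-2-methylphenyl with 2-fluorophenyl on a double-bonded chain carbon bound to an aromatic carbon gives a 3.4-fold higher number from compound 2 to compound 3 (0.54 log units; beyond the scatter) in this assay. Among these compounds, this is the only readable step in the set, and it shows that the number responds to the aryl group carried at this position, with the change here going toward weaker inhibition. The two group names differ both in the methyl and in where the fluoro stands, so this single step cannot be divided between them, and no measurement is available to explain it.

Steps involving compound 1, reported as "not active" (no number reported), cannot be read. As far as these compounds go, it remains open how this position would respond to a phenyl ring carrying only a methyl group, an amine or a carboxylic acid.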